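Cyano for Bromo on the Aryl Ring of Compound 2

The compounds below may be only part of what the source reports. "The series", "measured", "known", "first", "only" and "open" are said of these compounds alone.

Compound 2 `CC1=C(C(=O)OCC2CCN(C(=O)OC(C)(C)C)CC2)C(c2cccc(Br)c2)C2=C(CC(C)(C)CC2=O)N1` is the racemic form of compound 1 `CC1=C(C(=O)OCC2CCN(C(=O)OC(C)(C)C)CC2)[C@H](c2cccc(Br)c2)C2=C(CC(C)(C)CC2=O)N1`, which is drawn with a single configuration at the saturated ring carbon. In an assay on HEK293 cells for inhibition of neurogenic locus notch homolog protein 1 (Homo sapiens), read by a luciferase reporter and resazurin assay, with a stated time of 16 h (a higher number here means a weaker inhibitor, a lower number a stronger inhibitor), compound 1 gives 130 nM, and compound 2 gives 360 nM, the higher of the two numbers; the step of a 2.8-fold higher number from compound 1 to compound 2 (0.44 log units; beyond the scatter) goes with the fact that one of compounds 1 and 2 is drawn with a defined configuration and the other without, at the place where they differ. Compound 3 `CC1=C(C(=O)OCC2CCN(C(=O)OC(C)(C)C)CC2)C(c2cccc(C#N)c2)C2=C(CC(C)(C)CC2=O)N1` differs from compound 2 by cyano in place of bromo on an aromatic carbon, a cyano in place of bromo on an aromatic carbon, meta to a large group. Going by the values given here, no measured pair changes this group, so the only step known, that from compound 1 to compound 2, concerns a different place and gives no direct guide. Compound 3 is therefore expected to stay near compound 2, with a step of a 1.4-fold higher number from compound 2 to compound 3 (0.14 log units; within the scatter) that is estimated to lie at or just beyond the edge of the scatter. Compound 3 is estimated at 500 nM, within 150 nM to 1800 nM.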

Compound 3, half-maximal inhibitory concentration: 220 nM
For compound 3 the middle estimate is 2.3-fold (0.36 log units) above the measured one; low and high end bracket the measured number.
By their numbers in this assay, from the lowest: compounds 1, 3 and 2 (each within the scatter of the next, the first and the last beyond it).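

In this assay, going by these compounds alone, the change from 3-bromophenyl to 3-cyanophenyl gives the first reading at this aromatic carbon, where the earlier compounds differed only in how the stereocentre was drawn. The step, a 1.6-fold lower number from compound 2 to compound 3 (0.21 log units; within the scatter), shows that the two compounds cannot be told apart in this assay. Thus, for this pair, cyano, with two heavy atoms and a hydrogen-bond acceptor, can stand in place of bromo, which has one heavy atom and no acceptor, although nothing shown explains the outcome.

The compounds shown leave open whether an amine, a carboxylic acid or a longer chain would be tolerated at this aromatic carbon. They also leave open whether a form of compound 3 drawn with a single configuration would differ from compound 3 in this assay.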